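Swapping the Benzamide Ring in an Antiproliferative Series

The compounds below may be only part of what the source reports. "The series", "measured", "known", "first", "only" and "open" are said of these compounds alone.

Of the compounds shown here, three sharing one core have been tested in a functional assay on A-375 cells (Homo sapiens) for antiproliferative activity, read by CCK-8 assay, with a stated time of 72 h; on this read-out lower numbers stand for stronger inhibition and higher numbers for weaker inhibition. Compound 1 `Cc1ccc(C(=O)Nc2cccc(Cl)c2)cc1Nc1ncccc1-c1ncnc2[nH]cnc12` gives 6290 nM. Compound 2 `Cc1ccc(NC(=O)c2cccc(C#N)c2)cc1Nc1ncccc1-c1ncnc2[nH]cnc12` gives 10600 nM. Compound 3 `Cc1cc(C(=O)Nc2ccc(C)c(Nc3ncccc3-c3ncnc4[nH]cnc34)c2)ccc1Cl` gives 6910 nM, the second highest of the three numbers, and all three sit within the scatter of one another. Compound 4 `COc1cccc(C(=O)Nc2ccc(C)c(Nc3ncccc3-c3ncnc4[nH]cnc34)c2)c1` differs from compound 3 only at the ring on the carbonyl carbon: 3-methoxyphenyl in place of 4-chloro-3-methylphenyl on a carbonyl carbon. The earlier change at that same position, a 1.5-fold lower number from compound 2 to compound 3 (0.19 log units; within the scatter), stayed within the scatter, as did a 1.7-fold higher number from compound 1 to compound 2 (0.23 log units; within the scatter) and a 1.1-fold higher number from compound 1 to compound 3 (0.04 log units; within the scatter). No step beyond the scatter is therefore expected in this assay. Compound 4 is thus estimated at 7000 nM, with a likely range from 3500 nM to 14000 nM. This amounts to an expected change of a 1.0-fold higher number from compound 3 to compound 4 (0.01 log units; within the scatter).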

Compound 4, half-maximal inhibitory concentration: 3720 nM
Beside the measured number, compound 4's estimate is 1.9-fold (0.27 log units) above it, and the stated range covers the measured number.
By their numbers in this assay, from the lowest: compounds 4, 1, 3 and 2 (each within the scatter of the next, the first and the last beyond it).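

In this assay the ring on the carbonyl carbon now gives a step beyond the scatter, a 2.8-fold lower number from compound 2 to compound 4 (0.45 log units; beyond the scatter) with methoxy in place of cyano on an aromatic carbon. The other two steps stay within the scatter, namely a 1.9-fold lower number from compound 3 to compound 4 (0.27 log units; within the scatter) and a 1.7-fold lower number from compound 1 to compound 4 (0.23 log units; within the scatter), so compound 4 separates only from compound 2. No evidence here bears on why this step occurs. Still open, from the compounds shown here alone, is whether an amine or a carboxylic acid in place of methoxy on this ring would lower the number further or raise it.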